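The source may hold more compounds than are shown below. What is called first, only, known or untested is meant among the compounds shown, and "the series" means these compounds.

Measured compounds: compound 1 `C/C=C1/[C@H](O[C@@H]2O[C@H](COC(C)=O)[C@@H](OC(C)=O)[C@H](OC(C)=O)[C@H]2OC(C)=O)OC=C(C(=O)OC)[C@H]1CC(=O)OCCCCCCCCCCCCCCC` at 3810 nM. Compound 2 `C/C=C1/[C@H](O[C@@H]2O[C@H](CO)[C@@H](O)[C@H](O)[C@H]2O)OC=C(C(=O)OC)[C@H]1CC(=O)OCCc1ccc(OC)cc1` at > 20000 nM, a limit of the assay and not a number.

Among the measured compounds shown here, in a functional assay on SK-BR-3 cells (Homo sapiens) for antiproliferative activity, read by MTT assay, with a stated time of 72 h (a lower number here means a stronger inhibitor, a higher number a weaker inhibitor), compound 1 gives 3810 nM, the only numbered value shown. Compound 2 sits at a limit in this assay. Compound 3 `C/C=C1/[C@H](O[C@@H]2O[C@H](COC(C)=O)[C@@H](OC(C)=O)[C@H](OC(C)=O)[C@H]2OC(C)=O)OC=C(C(=O)OC)[C@H]1CC(=O)OCCC` differs from compound 1 by hydrogen in place of dodecyl on a saturated chain carbon, three bonds along the chain from an oxygen next to a carbonyl group. For the measured compounds named here, no step between measured compounds is available here, so the size of this change is uncertain. A weakening in this assay is expected, because compound 2 already sits at the limit of > 20000 nM in this assay, at which 1 of the 2 values shown sits. Compound 3 is therefore expected to give about 12000 nM, between 4000 nM and 30000 nM, a step of a 3.1-fold higher number from compound 1 to compound 3 (0.50 log units; beyond the scatter).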

Compound 3, half-maximal inhibitory concentration: 6600 nM
Beside the measured number, compound 3's estimate is 1.8-fold (0.26 log units) above it; the range from low to high includes it.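

Hydrogen in place of dodecyl, on a saturated chain carbon, three bonds along the chain from an oxygen next to a carbonyl group, gives a 1.7-fold higher number from compound 1 to compound 3 (0.24 log units; within the scatter) in this assay, so the dodecyl group can go without a step beyond the scatter. Among the compounds shown here, this pair is the first to read this chain on its own, with the shared core unchanged. Nothing shown bears on a cause for this result. Still open, as far as these compounds go, is whether an amine or a carboxylic acid at this place would give a step beyond the scatter.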